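Extending the side chain of inactive compound 3

The source may hold more compounds than are shown below. What is called first, only, known or untested is meant among the compounds shown, and "the series" means these compounds.

In a functional assay on A549 cells (Homo sapiens) for antiproliferative activity, read by MTT assay, with a stated time of 72 h (a higher number here means a weaker inhibitor, a lower number a stronger inhibitor), compound 1 (`O=C(N/N=C/c1ccccc1)Nc1ccc(Oc2ccnc3[nH]ccc23)c(F)c1`) gives 2500 nM and compound 2 (`O=C(N/N=C/c1ccc([N+](=O)[O-])cc1)Nc1ccc(Oc2ccnc3[nH]ccc23)c(F)c1`) gives 20 nM. Compound 3 (`CN(C)CCn1cccc1/C=N/NC(=O)Nc1ccc(Oc2ccnc3[nH]ccc23)c(F)c1`) has no number and is recorded only as "not active" (no number reported). Compound 4 (`CN1CCN(CCCn2cccc2/C=N/NC(=O)Nc2ccc(Oc3ccnc4[nH]ccc34)c(F)c2)CC1`) differs from it by (4-methylpiperazin-1-yl)methyl in place of dimethylamino on a saturated chain carbon, two bonds along the chain from an aromatic nitrogen, so that 2-(dimethylamino)ethyl becomes 3-(4-methylpiperazin-1-yl)propyl. For the measured compounds named here, the only measured step, a 130-fold lower number from compound 1 to compound 2 (2.10 log units; beyond the scatter), is large, but it is a different change, nitro in place of hydrogen on an aromatic carbon. It shows that one change can move the number far, yet it gives no size for this one. Going by the values given here, with no number for compound 3, no step can be sized, and a weak result is expected in this assay. For compound 4 the estimated value is 3000 nM, within a range of 500 nM to 20000 nM.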

Compound 4, half-maximal inhibitory concentration: 2200 nM
Compound 4: middle estimate off by 1.4-fold (0.13 log units), on the high side, within the range that was stated.
By their numbers in this assay, from the lowest: compound 2; then compounds 4 and 1 (each within the scatter of the next).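

Compound 3 carries no number, only the record "not active", and the step from it to compound 4 cannot be sized. Left open is how far 3-(4-methylpiperazin-1-yl)propyl in place of 2-(dimethylamino)ethyl moves the number. Nothing measured here explains the result.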